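This account rests on a few compounds, and the source may have more. Where it says the series, first, only, none or still open, it means among the compounds named here.

Of the compounds shown here, three sharing one core have been measured in a functional assay on CHO cells for antagonist activity at Orexin/Hypocretin receptor type 1 (Homo sapiens), read by FLIPR and calcium flux; a higher number here means a weaker inhibitor, a lower number a stronger inhibitor. Compound 1 `CCc1nc(Cl)c2n1CCN([C@@H](C(=O)NC)c1ccccc1)[C@H]2CCc1ccc(F)c(F)c1F` gives 30 nM. Compound 2 `CNC(=O)[C@@H](c1ccccc1)N1CCn2c(C3CC3)nc(Cl)c2[C@@H]1CCc1ccc(C(F)(F)F)cc1` gives 30 nM. Compound 3 `CNC(=O)[C@@H](c1ccccc1)N1CCn2c(C3CC3)nc(Cl)c2[C@@H]1CCc1ccc(C(F)(F)F)c(F)c1` gives 53 nM, the highest of the three numbers, although its gaps to compound 1 and to compound 2 both lie within the scatter. For the measured compounds named here, the only single-point step among them, a 1.8-fold higher number from compound 2 to compound 3 (0.25 log units; within the scatter), came from fluoro in place of hydrogen on an aromatic carbon. Compound 4 `CNC(=O)[C@@H](c1ccccc1)N1CCn2c(C3CC3)nc(Cl)c2[C@@H]1CCc1ccc(OC(F)F)c(F)c1` differs from compound 3 by difluoromethoxy in place of trifluoromethyl on an aromatic carbon. Going by the values given here, no measured step touches that group, so the data give no guide to how this assay responds to it; the step of a 1.1-fold higher number from compound 3 to compound 4 (0.05 log units; within the scatter) is therefore expected to stay small. Compound 4 is estimated at 60 nM, with a range from 25 nM to 150 nM.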

Compound 4, half-maximal inhibitory concentration: 170 nM
Estimate against measurement, compound 4: 2.8-fold (0.45 log units) below; the whole stated range lies below it.
By their numbers in this assay, from the lowest: compounds 1, 2 and 3 (each within the scatter of the next); then compound 4.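

In this assay this aromatic carbon, ortho to a fluoro group, proves sensitive to its substituent: difluoromethoxy in place of trifluoromethyl gives a 3.2-fold higher number from compound 3 to compound 4 (0.51 log units; beyond the scatter) and so, unlike the fluoro step, lies beyond the scatter. For the compounds shown here, the full change of aryl group, adding that fluoro as well, gives a 5.7-fold higher number from compound 2 to compound 4 (0.75 log units; beyond the scatter) and is the largest step so far. Nothing measured here accounts for this loss. Going by these compounds, how a methoxy or a nitrile on this carbon would read stays open, as does whether difluoromethoxy has the same effect without the fluoro group.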